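This account rests on a few compounds, and the source may have more. Where it says the series, first, only, none or still open, it means among the compounds named here.

Values so far in a functional assay on K562 cells (Homo sapiens) for cytotoxicity, read by spectrophotometry (a higher number here means a weaker inhibitor, a lower number a stronger inhibitor), are these
Compound 1 `CC(=O)O[C@@H](C[C@@H]1C(C)=CCC(=O)C1(C)C)/C(C)=C/[C@H](O)C/C=C(\C)CC[C@H]1C(C)(C)[C@@H](O)CC[C@]1(C)OC(C)=O` gives 14600 nM
Compound 2 `CC(=O)O[C@@H](C[C@H]1C(C)(C)C(=O)C=C[C@]1(C)O)/C(C)=C/[C@H](O)C/C=C(\C)CC[C@H]1C(C)(C)[C@@H](O[C@@H]2O[C@H](CO)[C@H](O)[C@H](O)[C@H]2O)CC[C@]1(C)OC(C)=O` gives > 100000 nM as a limit of the assay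

Compound 2 therefore carries no number, only a limit (the limit of > 100000 nM in this assay, at which 1 of the 2 values shown sits). Compound 3 (`CC(=O)O[C@@H](C[C@H]1C(C)(C)C(=O)C=C[C@]1(C)O)/C(C)=C/[C@H](O)C/C=C(\C)CC[C@H]1C(C)(C)[C@@H](O)CC[C@]1(C)OC(C)=O`) has not yet been measured. It differs from compound 2 by one change (hydrogen in place of 3,4,5-trihydroxy-6-(hydroxymethyl)oxan-2-yl on an oxygen on a saturated carbon), with hydrogen in place of 3,4,5-trihydroxy-6-(hydroxymethyl)oxan-2-yl on an oxygen on a saturated carbon, so that hydroxy stands where (3,4,5-trihydroxy-6-(hydroxymethyl)oxan-2-yl)oxy stood. Among the measured compounds shown here, no measured pair shows this change directly, so the size of the step in this assay rests on a thin base. For the measured compounds named here, the only numerical value in hand is that of compound 1 (14600 nM), and on that anchor a clear move toward a stronger inhibitor, beyond the usual scatter, is expected for compound 3. The estimated change is an at least 4.0-fold lower number from compound 2 to compound 3 (0.60 log units; beyond the scatter) on this reading. For compound 3 the expected value is 25000 nM within an estimated range of 8000 nM to 80000 nM in the same read-out.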

Compound 3, half-maximal inhibitory concentration: 27500 nM
Estimate against measurement, compound 3: 1.1-fold (0.04 log units) below, within the range that was stated.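

In this assay, among the compounds shown here, the hydroxy compound gives the first readable step for this oxygen on a saturated carbon: with hydrogen in place of 3,4,5-trihydroxy-6-(hydroxymethyl)oxan-2-yl, the number falls beyond the scatter (an at least 3.6-fold lower number from compound 2 to compound 3 (0.56 log units; beyond the scatter)). That step is only a minimum, because compound 2 has no number of its own and stands at a limit of the assay: the limit of > 100000 nM in this assay, at which 1 of the 3 values shown sits. The comparison at the other end of the molecule shows that 2-hydroxy-2,6,6-trimethyl-5-oxocyclohex-3-en-1-yl in place of 2,6,6-trimethyl-5-oxocyclohex-2-en-1-yl stays within the scatter (a 1.9-fold higher number from compound 1 to compound 3 (0.27 log units; within the scatter)), so compound 1 and compound 3 cannot be told apart here.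

On these data alone, how far the true value of compound 2 lies past its limit remains open, and with it the full size of the step from the oxanyl group to hydroxy. Also open, as far as these compounds go, is how an acetyl ester, a methyl ether or an amine would read at this position, and whether the same oxanyl group on the core of compound 1 would give a step of similar size.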